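The source may hold more compounds than are shown below. What is called first, only, known or untested is meant among the compounds shown, and "the series" means these compounds.

Measured so far:
compound 1 `Cc1ccc(NC(=O)CSc2snnc2-c2ccc(Cl)cc2Cl)c(Br)c1` — > 255000 nM
compound 2 `COc1ccc(-c2nnsc2SCC(=O)Nc2ccccc2Cl)cc1` — > 318000 nM
compound 3 `COc1ccc(-c2nnsc2SCC(=O)Nc2ccccc2[N+](=O)[O-])cc1` — >= 280000 nM

In an ADME assay on MT4 cells (Homo sapiens) for cytotoxicity (a higher number here means that more compound is tolerated, a lower number that less compound is tolerated), compound 3 gives >= 280000 nM, which is a limit of the assay rather than a number. The two other values are limits as well. In this assay compound 1 gives > 255000 nM, a limit. In this assay compound 2 gives > 318000 nM, also a limit. Compound 3 thus stands among three values none of which is a number, so no order among them can be read.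

Compound 4 `O=C(CSc1snnc1-c1ccc(Cl)cc1Cl)Nc1ccccc1[N+](=O)[O-]` is not yet measured. It differs from compound 3 in one place: 2,4-dichlorophenyl in place of 4-methoxyphenyl on an aromatic carbon. Within the data shown here, the only measured step, a step that the two limits leave unreadable from compound 2 to compound 3, concerns a different change, and its size is not readable from two limits. Compound 1 already carries the 2,4-dichlorophenyl group that enters here, and it too gave only a limit. Nothing measured therefore points to a readable step. The step from compound 3 to compound 4 in this assay is expected to be a number no higher from compound 3 to compound 4 (the limit leaves the size open), nothing beyond the scatter. Compound 4 is expected to give about 280000 nM in this assay, somewhere between 120000 nM and 500000 nM, most probably once more as a limit.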

Compound 4, half-maximal cytotoxic concentration: > 283000 nM
Compound 4: no number, only a limit; the forecaster's own chance of this, stated with the estimate: 75%; at least 1.0-fold (0.00 log units) between middle value and limit.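

In this assay compound 4 gives > 283000 nM, which is a limit and not a number. Compound 1 and compound 3 also give only limits, so neither step to compound 4 can be read. The compounds shown leave open at what concentration any of them harms the cells, and whether the changes between them shift that concentration.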